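Pyridinyl for Thiazolyl Sulfonamides on Two Pyrrole Cores

This account rests on a few compounds, and the source may have more. Where it says the series, first, only, none or still open, it means among the compounds named here.

Measured compounds:
Compound 1 `N#Cc1c(-c2ccccc2)cn(-c2ccc(S(=O)(=O)Nc3nccs3)cc2)c1NC(=O)CCC(=O)O`: 9120 nM
Compound 2 `N#Cc1c(-c2ccccc2)cn(-c2ccc(S(=O)(=O)Nc3ccccn3)cc2)c1NC(=O)CCC(=O)O`: 8320 nM
Compound 3 `Nc1nc(=O)[nH]c2c1c(-c1ccccc1)cn2-c1ccc(S(=O)(=O)Nc2nccs2)cc1`: 8320 nM

In a functional assay on MCF7 cells (Homo sapiens) for inhibition, read by sulforhodamine B assay, with a stated time of 24 h (a lower number here means a stronger inhibitor, a higher number a weaker inhibitor), compound 1 gives 9120 nM and compound 2 gives 8320 nM. The change between them is pyridin-2-yl in place of 1,3-thiazol-2-yl on a sulfonamide nitrogen, and it made a 1.1-fold lower number from compound 1 to compound 2 (0.04 log units; within the scatter). Compound 3 gives 8320 nM in this assay; its core differs from that of compound 1, and the difference between the two cores is not broken down here. Compound 4 `Nc1nc(=O)[nH]c2c1c(-c1ccccc1)cn2-c1ccc(S(=O)(=O)Nc2ccccn2)cc1` has not yet been measured. It arises from compound 3 by pyridin-2-yl in place of 1,3-thiazol-2-yl on a sulfonamide nitrogen, the same change as from compound 1 to compound 2, at the same kind of place. Because the earlier step was a 1.1-fold lower number from compound 1 to compound 2 (0.04 log units; within the scatter), compound 4 is expected to stay close to compound 3, with an estimated step of a 1.1-fold lower number from compound 3 to compound 4 (0.04 log units; within the scatter). Compound 4 is therefore estimated at 7600 nM in this assay, with a range from 4000 nM to 16000 nM.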

Compound 4, half-maximal inhibitory concentration: 3900 nM
The estimate for compound 4 lay 1.9-fold (0.29 log units) above the measured number; measured number outside the range, below it.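

In this assay, pyridin-2-yl in place of 1,3-thiazol-2-yl on a sulfonamide nitrogen gave a 2.1-fold lower number from compound 3 to compound 4 (0.33 log units; beyond the scatter). Set beside the earlier step, the change carried from one core to the other without a difference that can be told apart: the same change on two cores in this assay, a 1.1-fold lower number (0.04 log units; within the scatter) from compound 1 to compound 2 and a 2.1-fold lower number (0.33 log units; beyond the scatter) from compound 3 to compound 4, 1.9-fold (0.29 log units) apart, within the scatter of two such steps. This rests on two cores only, so it does not show that the change would lower the number on any further core, and the pair of compound 1 and compound 2 on its own shows no change beyond the scatter.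

The compounds shown leave open how a phenyl or a pyrimidin-2-yl group on the sulfonamide nitrogen would read on either core. They also leave open what a simple amine in place of the carboxylic acid chain of compound 2 would do.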